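Acetylation of a Ring Hydroxyl and Cytotoxicity in Lung Cells

The source may report more compounds than this note shows. Statements on the series, on what has been measured and on what is new or still open speak of the compounds shown alone.

Compound 1 `COc1ccc(C2=C(c3cc(OC)c(OC)c(OC)c3)C(=O)C(OC(C)=O)C2)cc1` and compound 2 `COc1ccc(C2=C(c3cc(OC)c(OC)c(OC)c3)C(=O)C(O)C2)cc1` share one core, while compound 3 `COc1cc(C2=C(c3cc(C)c(OC)c(C)c3)C(O)CC2=O)cc(OC)c1OC` and compound 4 `COc1cc(C2=C(c3cc(C)c(OC)c(C)c3)C(OC(C)=O)CC2=O)cc(OC)c1OC` share another; the difference between the two cores is not broken down here. In an ADME assay on L132 cells (Homo sapiens) for cytotoxicity, read by MTT assay, with a stated time of 72 h (on this read-out lower numbers stand for stronger inhibition and higher numbers for weaker inhibition), compound 2 gives < 1 ug/mL, which is a limit of the assay rather than a number. Compound 1 gives > 100 ug/mL, again a limit. The change between them acetyl in place of hydrogen on an oxygen on a saturated carbon produced an at least 100-fold higher number from compound 2 to compound 1 (2.00 log units; beyond the scatter). Compound 3 gives > 100 ug/mL, also a limit. Compound 4 carries the same change (acetyl in place of hydrogen on an oxygen on a saturated carbon). Because compound 3 already sits at the limit of > 100 ug/mL in this assay, at which 2 of the 3 values shown sit, compound 4 is expected to stay at that limit, with an estimated step of a number no higher from compound 3 to compound 4 (the limit leaves the size open). The estimated value for compound 4 is 100 ug/mL, expected to fall between 30 ug/mL and 300 ug/mL.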

Compound 4, half-maximal inhibitory concentration: > 100 ug/mL
Compound 4 was reported as a limit; the forecaster's own chance of this, stated with the estimate: 85%; the middle value sits exactly at the limit.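

In this assay compound 4 gives > 100 ug/mL, a limit. Compound 3 gives > 100 ug/mL, also a limit, so no step can be read between compound 3 and compound 4. The compounds shown leave open whether acetyl in place of hydrogen changes the number at all on the core of compound 3.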